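The source may report more compounds than this note shows. Statements on the series, on what has been measured and on what is new or still open speak of the compounds shown alone.

Among the compounds with values here, in a functional assay on cells (T-cell line, Homo sapiens) for inhibition (on this read-out higher numbers stand for weaker inhibition and lower numbers for stronger inhibition), compound 3 (`Clc1ccc(CCCN2CCC(COC(c3ccccc3)c3ccccc3)CC2)cc1`) gives 500 nM, the lowest of the three numbers so far and so the strongest inhibitor of the set. Compound 1 (`COc1ccc(CCCN2CCC(CNC(c3ccccc3)c3ccccc3)CC2)cc1`) gives 2800 nM and compound 2 (`COc1ccc(CCCN2CCC(COCC3CCCCC3)CC2)cc1`) gives 3000 nM, and the gaps from both to compound 3 lie beyond the usual scatter.

The next compound is compound 4 (`COc1cccc(CCCN2CCC(COC(c3ccccc3)c3ccccc3)CC2)c1`), which has 3-methoxyphenyl in place of 4-chlorophenyl on a saturated chain carbon, three bonds along the chain from an amine nitrogen in a ring. Within the data shown here, no measured pair isolates this change. Compound 1 and compound 2 both carry a methoxy group, but each also differs from compound 3 elsewhere, so they offer only a loose guide. Their values suggest a move towards a higher number rather than a lower one, though a step within the scatter cannot be excluded.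

In this assay, the expected change is a moderate loss of inhibition, estimated as a 1.8-fold higher number from compound 3 to compound 4 (0.26 log units; within the scatter). For compound 4, the estimated value is 900 nM, with an expected range of 300 nM to 2700 nM.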

Compound 4, half-maximal inhibitory concentration: 1500 nM
Compound 4: the middle estimate sits 1.7-fold (0.22 log units) below what was measured, and the stated range covers the measured number.
By their numbers in this assay, from the lowest: compound 3; then compounds 4, 1 and 2 (each within the scatter of the next).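

In this assay, within the data shown here, the exchange of 4-chlorophenyl for 3-methoxyphenyl on a saturated chain carbon, three bonds along the chain from an amine nitrogen in a ring, gives a 3.0-fold higher number from compound 3 to compound 4 (0.48 log units; beyond the scatter) and provides the first single-place comparison. The aryl group at this position therefore affects inhibition with the rest of the structure unchanged. The exchange alters both the substituent and its location on the ring, and no available evidence accounts for the step.

The effects of substituent and location remain unseparated; 3-chlorophenyl and 4-methoxyphenyl would address that directly. Also open, as far as these compounds go, is how unsubstituted phenyl or a pyridine ring would compare at this position.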